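Swapping a piperidine for a fluoroanilino group on the shared core

The source may hold more compounds than are shown below. What is called first, only, known or untested is meant among the compounds shown, and "the series" means these compounds.

Of the compounds shown here, three with a shared core have been tested in a functional assay on MCF7 cells (Homo sapiens) for inhibition, read by sulforhodamine B assay; on this read-out lower numbers stand for stronger inhibition and higher numbers for weaker inhibition. Compound 1 `O=C1C(N2CCCCC2)=CC(=O)c2c1nc1n2[C@H]2OC[C@@H](O)[C@H]2OC1` carries a piperidin-1-yl group on the core; in this assay compound 1 gives only a limit, > 8000 nM, and no number. Compound 2 `COc1ccc(NC2=CC(=O)c3nc4n(c3C2=O)[C@H]2OC[C@@H](O)[C@H]2OC4)cc1` instead carries a methoxy-substituted anilino group, and in this assay compound 2 gives 5420 nM. Compound 3 `O=C1C=C(Nc2ccc(Br)cc2)C(=O)c2c1nc1n2[C@H]2OC[C@@H](O)[C@H]2OC1` carries a bromo-substituted anilino group, and in this assay compound 3 gives 2580 nM. Going by the values given here, the one measured step between neighbours, a 2.1-fold lower number from compound 2 to compound 3 (0.32 log units; beyond the scatter), is modest but beyond the scatter.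

Compound 4 `O=C1C(Nc2cccc(F)c2)=CC(=O)c2c1nc1n2[C@H]2OC[C@@H](O)[C@H]2OC1` has not yet been measured. It differs from compound 1 in one place: (3-fluorophenyl)amino in place of piperidin-1-yl on a double-bonded ring carbon. Among the compounds with values here, no measured step covers exactly this change; what is known is that compound 1 sits at the limit (the limit of > 8000 nM in this assay, at which 1 of the 3 values shown sits), while the two anilino compounds, compound 2 and compound 3, give numbers rather than limits, and that bromo in place of methoxy gave a 2.1-fold lower number from compound 2 to compound 3 (0.32 log units; beyond the scatter). A fluorine-bearing anilino group is therefore expected to land between the values of compound 2 and compound 3, so compound 4 is expected to show an at least 2.2-fold lower number from compound 1 to compound 4 (0.35 log units; beyond the scatter), that is a lower number than the limit of compound 1. The estimated value for compound 4 is 3500 nM, within a range of 1500 nM to 8000 nM.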

Compound 4, half-maximal inhibitory concentration: > 4000 nM
Compound 4 ended at the assay's limit; the forecaster's own chance of this, stated with the estimate: 15%; middle value at least 1.1-fold (0.05 log units) from the limit.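

Compound 1 and compound 4 both end at limits in this assay and not at numbers, and the step from one to the other cannot be read. The compounds shown leave open what number compound 4 would give, and so how (3-fluorophenyl)amino compares with piperidin-1-yl on the shared core.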